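The source may report more compounds than this note shows. Statements on the series, on what has been measured and on what is new or still open speak of the compounds shown alone.

Measured compounds in an assay on CHO cells for displacement of a labelled ligand from Alpha-2C adrenergic receptor (Homo sapiens); on this read-out higher numbers stand for weaker inhibition and lower numbers for stronger inhibition:

- compound 1 `CC(C)Oc1ccccc1OC(C)C1=NCCN1`: 398 nM
- compound 2 `COc1ccccc1OC(C)C1=NCCN1`: 832 nM
- compound 3 `CC(Oc1ccccc1S(C)(=O)=O)C1=NCCN1`: 3800 nM

Compound 3 gives the highest number of the three in this assay. Its nearest neighbour on the numbers is compound 2, a step of a 4.6-fold higher number from compound 2 to compound 3 (0.66 log units; beyond the scatter); the furthest is compound 1, a step of a 9.5-fold higher number from compound 1 to compound 3 (0.98 log units; beyond the scatter). Between the two alkoxy compounds the step is a 2.1-fold higher number from compound 1 to compound 2 (0.32 log units; beyond the scatter).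

Compound 4 `CC(=O)c1ccccc1OC(C)C1=NCCN1` is not yet measured. It differs from compound 3 in one place: acetyl in place of methylsulfonyl on an aromatic carbon.

Among the measured compounds shown here, no measured step swaps methylsulfonyl for acetyl, so none bears on this change directly. What the series shows is that both measured substitutions onto the same aromatic carbon, isopropoxy and methoxy in place of methylsulfonyl, lower the number, by a 9.5-fold higher number from compound 1 to compound 3 (0.98 log units; beyond the scatter) reversed and a 4.6-fold higher number from compound 2 to compound 3 (0.66 log units; beyond the scatter) reversed. Acetyl is a third group at that position with no counterpart among the measured compounds. The expectation is a step in this assay in the same direction as those two, smaller than either, and possibly not beyond the scatter.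

For compound 4 the estimated value is 2000 nM, with a range from 600 nM to 6500 nM, which corresponds to an expected step of a 1.9-fold lower number from compound 3 to compound 4 (0.28 log units; within the scatter).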

Compound 4, inhibition constant: 7410 nM
Compound 4: the middle estimate sits 3.7-fold (0.57 log units) below what was measured, and the stated range ends below it.
By their numbers in this assay, from the lowest: compound 1; then compound 2; then compounds 3 and 4 (each within the scatter of the next).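

In this assay, acetyl in place of methylsulfonyl on this aromatic carbon gives a 2.0-fold higher number from compound 3 to compound 4 (0.29 log units; within the scatter) and so does not separate the two groups, although acetyl has one heavy atom fewer and one hydrogen-bond acceptor fewer. Acetyl also stands well apart from both alkoxy groups, with an 8.9-fold higher number from compound 2 to compound 4 (0.95 log units; beyond the scatter) and a 19-fold higher number from compound 1 to compound 4 (1.27 log units; beyond the scatter) as the steps, so the four compounds fall into two sets: isopropoxy and methoxy give the lower numbers, methylsulfonyl and acetyl the higher ones, and none of the four goes against this split. No supporting data are available that would explain this split or why methylsulfonyl and acetyl cannot be told apart here.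

On these data alone, with only four groups at this position, it remains open whether the split follows the oxygen attached to the aromatic carbon or some other feature of the groups, and an amine, a carboxylic acid or a longer alkoxy chain such as butoxy would test this. The compounds shown also leave open whether the same split would hold if the rest of the shared core were changed.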